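This account rests on a few compounds, and the source may have more. Where it says the series, first, only, none or still open, it means among the compounds named here.

Measured compounds:
- Compound 1, `CC(=O)Nc1ccc(S(=O)(=O)Oc2ccccc2I)cc1`: 27000 nM
- Compound 2, `CC(C)c1ccccc1OS(=O)(=O)c1ccc(NC(=O)CCCCl)cc1`: 5100 nM
- Compound 3, `O=C(CCCCl)Nc1ccc(S(=O)(=O)Oc2ccccc2I)cc1`: 7200 nM

All three were tested in a functional assay on M21 cells (Homo sapiens) for antiproliferative activity, read by sulforhodamine B assay, with a stated time of 48 h; on this read-out lower numbers stand for stronger inhibition and higher numbers for weaker inhibition. Compound 3 stands second highest of the three numbers: its nearest neighbour is compound 2, whose value lies within the scatter of it, while compound 1 sits farther away with a clearly higher number.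

The next compound, compound 4, `O=C(NCC1CCCC1)Nc1ccc(S(=O)(=O)Oc2ccccc2I)cc1`, differs from compound 3 in one place: (cyclopentylmethyl)amino in place of 3-chloropropyl on a carbonyl carbon. In plainer terms, the chain carrying a chlorine that hangs from the carbonyl is swapped for a nitrogen bearing a cyclopentylmethyl group, so the amide of compound 3 becomes a urea in compound 4.

Going by the values given here, two measured steps bear on this. The step of a 3.8-fold lower number from compound 1 to compound 3 (0.57 log units; beyond the scatter) shows that what hangs from the carbonyl can move the number modestly. The step of a 1.4-fold higher number from compound 2 to compound 3 (0.15 log units; within the scatter) shows that a swap elsewhere on the molecule left the number within the scatter. Neither step is of the same kind as the amide-to-urea change, so the direction is uncertain; a step no larger than modest is expected in this assay, most likely a small one.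

Compound 4 is therefore estimated at 5000 nM, with a range from 1500 nM to 20000 nM, a step of a 1.4-fold lower number from compound 3 to compound 4 (0.16 log units; within the scatter).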

Compound 4, half-maximal inhibitory concentration: 7600 nM
The estimate for compound 4 lay 1.5-fold (0.18 log units) below the measured number, within the range that was stated.
By their numbers in this assay, from the lowest: compounds 2, 3 and 4 (each within the scatter of the next); then compound 1.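

In this assay, putting (cyclopentylmethyl)amino in place of 3-chloropropyl on the carbonyl carbon turns the amide into a urea and gives a 1.1-fold higher number from compound 3 to compound 4 (0.02 log units; within the scatter), so this place takes a bigger group, with a five-membered ring and a hydrogen-bond donor, and the number stays within the scatter. Measured against the methyl group of compound 1, the same urea group gives a 3.6-fold lower number from compound 1 to compound 4 (0.55 log units; beyond the scatter), which can be set beside a 3.8-fold lower number from compound 1 to compound 3 (0.57 log units; beyond the scatter) and shows that the chlorine of the 3-chloropropyl chain is not required for a number lower than that of compound 1. Nothing measured on these compounds explains why two such different groups land so close together.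

The compounds shown leave open which part of the new group matters, since a urea carrying a plain butyl chain or a phenyl ring could separate the nitrogen from the cyclopentylmethyl part. They also leave open whether an amine or a carboxylic acid at the end of the chain on the carbonyl carbon would keep the number in this range or move it well away.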